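Swapping fluoro for trifluoromethyl on the pyrazole of compound 3

The source may report more compounds than this note shows. Statements on the series, on what has been measured and on what is new or still open speak of the compounds shown alone.

Of the compounds shown here, three sharing one core have been measured in an assay on cells for displacement of a labelled ligand from Glucagon receptor (Homo sapiens), in the presence of a further agent that is not named here; a lower number here means a stronger inhibitor, a higher number a weaker inhibitor. Compound 1 `CCC(Oc1ccc(-n2cc(C(F)(F)F)cn2)cc1)c1ccc(C(=O)NCCC(=O)O)cc1` gives 1400 nM. Compound 2 `O=C(O)CCNC(=O)c1ccc(C(Oc2ccc(-n3cc(C(F)(F)F)cn3)cc2)C2CCCC2)cc1` gives 420 nM. Compound 3 `CCCC(Oc1ccc(-n2cc(F)cn2)cc1)c1ccc(C(=O)NCCC(=O)O)cc1` gives 1700 nM, the highest of the three numbers, although the gap to compound 1 lies within the scatter, while the gap to compound 2 lies beyond it. Among the measured compounds shown here, the only measured step between neighbours is a 3.3-fold lower number from compound 1 to compound 2 (0.52 log units; beyond the scatter), which concerns the chain carbon, not the five-membered ring.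

Compound 4 `CCCC(Oc1ccc(-n2cc(C(F)(F)F)cn2)cc1)c1ccc(C(=O)NCCC(=O)O)cc1` differs from compound 3 in one place: trifluoromethyl in place of fluoro on an aromatic carbon. For the measured compounds named here, no measured pair isolates this change, so the step 1>2 offers no direct guide. Compound 1 and compound 3 differ both here and in the chain, yet their numbers sit within the scatter of each other, which suggests the ring substituent matters little. Compound 4 is therefore expected to show a 1.4-fold lower number from compound 3 to compound 4 (0.15 log units; within the scatter), a step not beyond the scatter. The estimate for compound 4 in this assay is 1200 nM, within a range from 500 nM to 3000 nM.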

Compound 4, inhibition constant: 890 nM
The estimate for compound 4 lay 1.3-fold (0.13 log units) above the measured number; the measured number falls inside the stated range.
By their numbers in this assay, from the lowest: compound 2; then compounds 4, 1 and 3 (each within the scatter of the next).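

Among the compounds shown here, compound 3 and compound 4 form the first pair that isolates this change on the five-membered aromatic ring, and in this assay trifluoromethyl and fluoro cannot be told apart there (a 1.9-fold lower number from compound 3 to compound 4 (0.28 log units; within the scatter)). The chain carbon is also clearer: the step from ethyl to propyl stays within the scatter (a 1.6-fold lower number from compound 1 to compound 4 (0.20 log units; within the scatter)), whereas the step from cyclopentyl to propyl lies beyond it (a 2.1-fold higher number from compound 2 to compound 4 (0.33 log units; beyond the scatter)), so among these compounds only the cyclopentyl group sets a compound apart. No measurement at hand explains either result.

On these data alone, whether a group of a different kind on this ring carbon, such as a nitrile or an amine, would shift the number remains open. So does whether fluoro and trifluoromethyl would still match with cyclopentyl on the chain carbon.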